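The source may hold more compounds than are shown below. What is called first, only, known or untested is meant among the compounds shown, and "the series" means these compounds.

Compound 1 `CSc1nncc2c(C)nc(C(C)C)n12` — > 48000 nM
Compound 2 `CCc1nc(C)c2cnn(CC)c(=O)n12` — 75600 nM
Compound 3 `CSc1nnc(-c2ccccc2)c2c(C)nc(C(C)C)n12` — > 48000 nM

In a functional assay for inhibition, with Homo sapiens as the target (a lower number here means a stronger inhibitor, a higher number a weaker inhibitor), compound 1 gives only a limit, > 48000 nM. Compound 3 likewise reaches only a limit, > 48000 nM. Compound 2 gives 75600 nM. Going by the values given here, the only step between measured compounds, a step that the two limits leave unreadable from compound 1 to compound 3, cannot be read because the limit of > 48000 nM in this assay, at which 2 of the 3 values shown sit, holds both of its ends. Compound 4 `CSc1nncc2c(C)ncn12` differs from compound 1 by hydrogen in place of isopropyl on an aromatic carbon. Among the compounds with values here, no measured step bears on this change, and nothing among the three measured compounds moves away from the weak end of the scale, so the step that the limit leaves unreadable from compound 1 to compound 4 is expected to stay within the scatter. Compound 4 is therefore estimated at 60000 nM, in a range from 20000 nM to 200000 nM, most likely reported once more as a limit.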

Compound 4, half-maximal inhibitory concentration: > 48000 nM
Compound 4 was reported as a limit; the forecaster's own chance of this, stated with the estimate: 80%; the middle value does not contradict the limit.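

Compound 1 and compound 4 both end in a limit, so no step can be read from one to the other, because both rest on the same limit: the limit of > 48000 nM in this assay, at which 3 of the 4 values shown sit.

On these data alone, whether hydrogen in place of isopropyl changes inhibition in this assay at all remains open.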